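Cytotoxicity Outlook for a New Analogue of Compound 1

The source may hold more compounds than are shown below. What is called first, only, known or untested is meant among the compounds shown, and "the series" means these compounds.

compound 1 `CCN(CC)c1cc2[nH]c(C3CCCCC3)nc2cc1NC(=O)c1ccc(OC(F)F)cc1`: > 100 ug/mL
compound 2 `CN(C)c1cc2[nH]c(C3CCCCC3)nc2cc1NC(=O)c1ccc(OC(F)F)cc1`: > 100 ug/mL
compound 3 `CCCCOC(=O)Nc1cc2nc(C3CCCCC3)[nH]c2cc1N(CC)CCN(C)C`: > 100 ug/mL

In an ADME assay on Vero cells (Chlorocebus sabaeus) for cytotoxicity, read by resazurin assay, with a stated time of 3 days (on this read-out lower numbers stand for stronger inhibition and higher numbers for weaker inhibition), compound 1 gives only a limit rather than a number. The same holds for compound 2, and for compound 3, so every measured value sits at the limit of > 100 ug/mL in this assay, at which 3 of the 3 values shown sit. Among the compounds with values here, the one comparison available, a step that the two limits leave unreadable from compound 1 to compound 2, therefore cannot be sized. Compound 1 and compound 3 are not linked by a single change, and their values show only that both reach the limit.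

Compound 4 `CCOCCOC(=O)Nc1cc2nc(C3CCCCC3)[nH]c2cc1N(CC)CC` differs from compound 1 by 2-ethoxyethoxy in place of 4-(difluoromethoxy)phenyl on a carbonyl carbon. Within the data shown here, nothing measured here reaches beyond the limit in this assay, so no step of any size has yet been seen, and no direction can be read from the data. The expectation is that compound 4 will also stop at the limit, because compound 3 already carries an oxygen-bearing chain on the carbonyl carbon and shows > 100 ug/mL. Compound 4 is estimated at 100 ug/mL, with a range from 50 ug/mL to 200 ug/mL. The step this estimate implies, a number no higher from compound 1 to compound 4 (the limit leaves the size open), is expected to lie within the scatter.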

Compound 4, half-maximal inhibitory concentration: > 100 ug/mL
Compound 4: a limit, no number (the forecaster's own chance of this, stated with the estimate: 85%); the middle value sits exactly at the limit.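

Compound 1 and compound 4 each give only a limit, not a number, in this assay, so the step between them cannot be read. The compounds shown leave open at what concentration, if any, each would harm these cells, because all stop at the same point: the limit of > 100 ug/mL in this assay, at which 4 of the 4 values shown sit.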